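Swapping amino for methylsulfanyl in an inactive nucleoside series

This account rests on a few compounds, and the source may have more. Where it says the series, first, only, none or still open, it means among the compounds named here.

In a functional assay on L1210 cells (Mus musculus) for inhibition (a higher number here means a weaker inhibitor, a lower number a stronger inhibitor), compound 1 `C=C1[C@@H](O)[C@H](n2ccc(=O)[nH]c2=O)O[C@@H]1CO` gives > 500000 nM, which is a limit and not a number. Compound 2 `C=C1[C@@H](O)[C@H](n2cnc3c(N)nc(N)nc32)O[C@@H]1CO` gives > 200000 nM, which is also a limit. Compound 2 therefore has no measured potency, and the two limits cannot be ranked against each other.

The next compound is compound 3 `C=C1[C@@H](O)[C@H](n2cnc3c(SC)nc(N)nc32)O[C@@H]1CO`, which carries methylsulfanyl in place of amino on an aromatic carbon of the shared core (methylsulfanyl in place of amino on an aromatic carbon). The amino group that remains on that ring is unchanged. Among the measured compounds shown here, no measured step shows what this swap does, so no strong shift in either direction can be justified.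

In this assay, the expected step is a number no higher from compound 2 to compound 3 (the limit leaves the size open), with no change beyond the scatter anticipated. A further limit in place of a number would not be surprising. For compound 3, the estimated value is 200000 nM, with an expected range of 60000 nM to 500000 nM.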

Compound 3, half-maximal inhibitory concentration: > 500000 nM
Compound 3 ended at the assay's limit; the forecaster's own chance of this, stated with the estimate: 65%; at least 2.5-fold (0.39 log units) between middle value and limit.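

Compound 3 gives > 500000 nM in this assay, which is a limit. Compound 2 also stands only at a limit, so no step can be read between compound 2 and compound 3. The compounds shown leave open what methylsulfanyl in place of amino does to potency.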